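Replacing Cyclopropyl with 4-Fluorophenyl on the Sulfonyl Sulfur

This account rests on a few compounds, and the source may have more. Where it says the series, first, only, none or still open, it means among the compounds named here.

Compound 1 `CCN(CC)c1ccc2cc(C(=O)c3ccc(N4CCN(C(=O)CN5CCN(C(=O)CCl)CC5)CC4)cc3)oc2c1` gives 1630 nM in a functional assay on SGC-7901 cells (Homo sapiens) for cytotoxicity, read by MTT assay, with a stated time of 48 h (on this read-out lower numbers stand for stronger inhibition and higher numbers for weaker inhibition), while compound 2 `CCN(CC)c1ccc2cc(C(=O)c3ccc(N4CCN(C(=O)CN5CCN(S(=O)(=O)C6CC6)CC5)CC4)cc3)oc2c1` gives 15300 nM in this assay, the highest of the two numbers measured, reached by the step of a 9.4-fold higher number from compound 1 to compound 2 (0.97 log units; beyond the scatter). Compound 3 `CCN(CC)c1ccc2cc(C(=O)c3ccc(N4CCN(C(=O)CN5CCN(S(=O)(=O)c6ccc(F)cc6)CC5)CC4)cc3)oc2c1` differs from compound 2 by 4-fluorophenyl in place of cyclopropyl on a sulfonyl sulfur. Among the measured compounds shown here, no measured step touches the substituent on the sulfonyl sulfur, so the one known step offers no guide, and nothing points in either direction. For compound 3 the expected step is therefore a 1.0-fold lower number from compound 2 to compound 3 (0.01 log units; within the scatter), none beyond the scatter. Compound 3 is estimated at 15000 nM, within a range of 5000 nM to 45000 nM.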

Compound 3, half-maximal inhibitory concentration: > 40000 nM
Compound 3 gave a limit, no number; the forecaster's own chance of this, stated with the estimate: 5%; at least 2.6-fold (0.42 log units) between middle value and limit.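

Compound 3 gave a limit, not a number, in this assay: the limit of > 40000 nM in this assay, at which 1 of the 3 values shown sits.
The earlier compounds shown here did not show that the group on the sulfonyl sulfur affects this read-out: 4-fluorophenyl in place of cyclopropyl gives an at least 2.6-fold higher number from compound 2 to compound 3 (0.41 log units; beyond the scatter) and moves the result further from compound 1. Measured directly against (chloromethyl)carbonyl, (4-fluorophenyl)sulfonyl gives an at least 24-fold higher number from compound 1 to compound 3 (1.38 log units; beyond the scatter) on the ring nitrogen.

As far as these compounds go, the true value of compound 3 remains unknown. Also open, from the compounds shown here alone, is how a methyl or unsubstituted phenyl on the sulfonyl sulfur, or a bromoacetyl group on that nitrogen, would read here.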